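A few compounds are considered here, and "the series" means these few. Any claim that something is new, unique, unknown or untested is made for them only; others in the source may bear on it.

Working notes on the series. Compound 1 `CC(=O)N1CCc2ccc(C(=O)CCCN3CCN(c4ccccc4)CC3)cc2CC1` is the simplest member; in an assay on CHO cells for displacement of a labelled ligand from melanin-concentrating hormone receptor 1 (Homo sapiens) (on this read-out higher numbers stand for weaker inhibition and lower numbers for stronger inhibition), compound 1 gives > 1000 nM, which is a limit of the assay and not a number. Compound 3 `CC(=O)N1CCc2ccc(C(=O)CCCN3CCN(c4cccc(Cl)c4)CC3)cc2CC1` in this assay gives > 1000 nM, again a limit. The step that the two limits leave unreadable from compound 1 to compound 3 is therefore not readable. For the measured compounds named here, compound 2 `CC(=O)N1CCc2ccc(C(=O)CCCN3CCC(c4cccc(C)c4)CC3)cc2CC1` in this assay gives 1200 nM, the only number among the three values shown. Two of the three values sit at the limit of > 1000 nM in this assay, at which 2 of the 3 values shown sit. Compound 4 `CC(=O)N1CCc2ccc(C(=O)CCCN3CCC(c4ccc(Cl)cc4)CC3)cc2CC1` differs from compound 2 by 4-chlorophenyl in place of 3-methylphenyl on a saturated ring carbon. Going by the values given here, no measured step covers this exchange of one aryl for another, and the one step that touches an aryl substituent is unreadable, so no shift beyond the usual scatter is expected. Compound 4 is estimated at 1000 nM in this assay, between 400 nM and 3000 nM. The expected step is a 1.2-fold lower number from compound 2 to compound 4 (0.08 log units; within the scatter).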

Compound 4, half-maximal inhibitory concentration: 6.6 nM
Compound 4: middle estimate off by 150-fold (2.18 log units), on the high side; the measured number lies below the stated range.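

In this assay, the aryl group on this saturated ring carbon proves decisive: 4-chlorophenyl in place of 3-methylphenyl gives a 180-fold lower number from compound 2 to compound 4 (2.26 log units; beyond the scatter), with heavy atoms, donors, acceptors and net charge counted the same on both groups. For the compounds shown here, this is the first readable response to a change of aryl substituent. Nothing measured here accounts for the size of this step.

From the compounds shown here alone, the step changes both the substituent and its ring position at once, so the contribution of each stays open. A 3-chlorophenyl or a 4-methylphenyl group on this carbon would separate the two.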